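Replacing the azetidine amide with an oxadiazolyl piperazine

The source may hold more compounds than are shown below. What is called first, only, known or untested is meant among the compounds shown, and "the series" means these compounds.

Compounds measured so far:
compound 1 `CC(C)c1noc(N2CCN(C(=O)[C@@H]3CCCN(S(=O)(=O)c4ccc(S(=O)(=O)C(C)C)cc4)C3)CC2)n1`, 30 nM
compound 2 `CCN(CC)S(=O)(=O)c1ccc(S(=O)(=O)N2CCC[C@@H](C(=O)N[C@@H]3CCN(C(=O)OC(C)(C)C)C3)C2)cc1`, 500 nM
compound 3 `CCN(CC)S(=O)(=O)c1ccc(S(=O)(=O)N2CCC[C@@H](C(=O)NC3CN(C(=O)C4CC4)C3)C2)cc1`, 3100 nM

In a functional assay on MIA PaCa-2 cells (Homo sapiens) for inhibition, read by MTT assay, with a stated time of 3 days (on this read-out lower numbers stand for stronger inhibition and higher numbers for weaker inhibition), compound 3 gives the highest of the three numbers; its nearest neighbour is compound 2, its furthest compound 1. Compound 4 `CCN(CC)S(=O)(=O)c1ccc(S(=O)(=O)N2CCC[C@@H](C(=O)N3CCN(c4nc(C)no4)CC3)C2)cc1` differs from compound 3 in one place: 4-(3-methyl-1,2,4-oxadiazol-5-yl)piperazin-1-yl in place of (1-(cyclopropylcarbonyl)azetidin-3-yl)amino on a carbonyl carbon. Within the data shown here, the only measured step that touches the same part of the molecule is a 6.2-fold higher number from compound 2 to compound 3 (0.79 log units; beyond the scatter), a change on the amide side that moved the number well beyond the scatter. Compound 1 carries the same kind of oxadiazolyl piperazine on its carbonyl and gives the lowest number of the set, though it also differs from compound 4 elsewhere, so no single step can be read from it. From this, a lower number is expected for compound 4, and the step is estimated as a 21-fold lower number from compound 3 to compound 4 (1.32 log units; beyond the scatter). In this assay compound 4 is therefore estimated at 150 nM, with a range from 40 nM to 600 nM.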

Compound 4, half-maximal inhibitory concentration: 200 nM
The estimate for compound 4 lay 1.3-fold (0.12 log units) below the measured number; measured number inside the range.
By their numbers in this assay, from the lowest: compound 1; then compound 4; then compound 2; then compound 3.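

In this assay, exchanging the (1-(cyclopropylcarbonyl)azetidin-3-yl)amino group for 4-(3-methyl-1,2,4-oxadiazol-5-yl)piperazin-1-yl on the carbonyl carbon gives a 16-fold lower number from compound 3 to compound 4 (1.19 log units; beyond the scatter). Earlier, this side of the molecule had shown only a rise in the number, a 6.2-fold higher number from compound 2 to compound 3 (0.79 log units; beyond the scatter), so the new step is the first measured one here to go downward, and it does so with the rest of the molecule unchanged and with the entering group carrying no hydrogen-bond donor. No measurement shown accounts for the size of this step.

The change replaces the whole group at once, so the compounds shown do not separate the contribution of the piperazine from that of the oxadiazole. An acetyl group or a pyrimidine ring on the piperazine in place of the 3-methyl-1,2,4-oxadiazol-5-yl group would bear on that question.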